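A few compounds are considered here, and "the series" means these few. Any claim that something is new, unique, unknown or untested is made for them only; others in the source may bear on it.

Measured compounds, each with its result:

Compound 1, `N=C(N)NCCC[C@H](NC(=O)CN(c1ncnc2c1ncn2C1CCCCO1)C1CC1)C(=O)OCc1ccccc1`: 61.6%
Compound 2, `O=C(CN(c1ncnc2c1ncn2C1CCCCO1)C1CC1)N[C@@H](CO)C(=O)OCc1ccccc1`: 32.2%
Compound 3, `O=C(CN(c1nc(Cl)nc2[nH]cnc12)C1CC1)N[C@@H](CC(=O)OCc1ccccc1)C(=O)OCc1ccccc1`: 15.6%

All three were tested in a functional assay on the whole organism (Tail, strain ICR) with Mus musculus as the target, in the tail flick test, with a stated time of 90 min, at a dose of 25 umol/kg by the oral route; on this read-out higher numbers stand for a stronger effect at the one dose given and lower numbers for a weaker effect. Compound 3 stands lowest of the three numbers: compound 2 lies nearest to it and compound 1 furthest, and both gaps exceed the usual scatter. Compound 4, `CC(C)[C@H](NC(=O)CN(c1nc(Cl)nc2[nH]cnc12)C1CC1)C(=O)OCc1ccccc1`, has not yet been measured. It differs from compound 3 in one place: isopropyl in place of (benzyloxycarbonyl)methyl on a saturated chain carbon bound to an amide-type nitrogen and a carbonyl carbon.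

For the measured compounds named here, only one measured step exists, and it does not match this change. From compound 1 to compound 2 an oxygen atom replaced a group of six heavy atoms on a saturated chain carbon two bonds along the chain from an amide-type nitrogen and a carbonyl carbon, which gave a number 29.4 percentage points lower from compound 1 to compound 2 (beyond the scatter). That step shows that exchanging the group on this side chain can shift the result by a modest amount, but it says nothing about an exchange of a benzyl ester for an isopropyl at the carbon bound to the amide-type nitrogen itself. The direction for compound 4 is therefore open; a shift of modest size in either direction, or none beyond the scatter, would fit what is known.

Taking compound 3 as the starting point, compound 4 is expected to give 22%, within a range from 5% to 50%. This estimate means a step of a number 6.4 percentage points higher from compound 3 to compound 4 (within the scatter), an expected change no larger than the scatter.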

Compound 4, a percentage reported as activity, at one dose (the size of the read-out at that dose, not a potency): 51.3%
Estimate against measurement, compound 4: 29.3 percentage points below, and the stated range ends below it.
By their numbers in this assay, from the lowest: compound 3; then compound 2; then compound 4; then compound 1.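

In this assay, putting isopropyl in place of (benzyloxycarbonyl)methyl on a saturated chain carbon bound to an amide-type nitrogen and a carbonyl carbon gives a number 35.7 percentage points higher from compound 3 to compound 4 (beyond the scatter) and counts as a large step. For the compounds shown here, this is the first direct sign that the group on this carbon matters for the result, whereas the earlier step, a number 29.4 percentage points lower from compound 1 to compound 2 (beyond the scatter) and modest in size, concerned a different place on the chain. It also shows that the larger group is not needed for a higher number here, since isopropyl has fewer heavy atoms and no ring, against a six-membered aromatic ring in the group it replaces, although no measurement at hand explains the rise.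

This single exchange changes size, ring and hydrogen-bond acceptors together, so it cannot show which of these differences counts. It also leaves open how a methyl, a longer carbon chain, a carboxylic acid or an amine on this same carbon would compare, and whether isopropyl would give a similar rise on the core of compound 1.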